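The source may report more compounds than this note shows. Statements on the series, on what has been measured and on what is new or still open speak of the compounds shown alone.

Measured compounds:
Compound 1 `O=C(CSc1cccc(O)c1)Nc1ccc2nc(NC(=O)c3cc(Cl)cc(Cl)c3)sc2c1`: 5440 nM
Compound 2 `O=C(CSc1cccc(O)c1)Nc1ccc2nc(NC(=O)c3cccs3)sc2c1`: 7020 nM
Compound 3 `Cc1ccc(SCC(=O)Nc2ccc3nc(NC(=O)c4ccc(C(F)(F)F)cc4)sc3c2)c(C)c1`: 320 nM

In a functional assay on HCT-116 cells (Homo sapiens) for antiproliferative activity, read by MTT assay, with a stated time of 72 h (on this read-out lower numbers stand for stronger inhibition and higher numbers for weaker inhibition), compound 2 gives 7020 nM, the highest number among the three measured compounds. Its nearest neighbour is compound 1, whose 5440 nM lies within the scatter of it, so the two cannot be told apart. Compound 3 differs from compound 2 in several places, and its number is far lower, beyond the scatter: compound 3 gives 320 nM.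

Compound 4 `O=C(CSc1cccc(O)c1)Nc1ccc2nc(NC(=O)c3ccccc3)sc2c1` has not yet been measured. It differs from compound 2 in a single spot: phenyl in place of thiophen-2-yl on a carbonyl carbon. The thiophen-2-yl leaves, a phenyl enters, and the spot is a carbonyl carbon whose other neighbour is an amide-type nitrogen, so that a (thiophen-2-yl)carbonyl becomes a benzoyl.

Among the compounds with values here, only one measured step speaks to this spot: a 1.3-fold higher number from compound 1 to compound 2 (0.11 log units; within the scatter). Swapping one aromatic ring for another on that carbonyl carbon left the number essentially where it was. Compound 4 repeats the same kind of swap, so no step beyond the scatter is expected in this assay in either direction. Compound 4 is therefore estimated at 6500 nM, with a range from 3000 nM to 14000 nM, which amounts to an expected 1.1-fold lower number from compound 2 to compound 4 (0.03 log units; within the scatter).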

Compound 4, half-maximal inhibitory concentration: 41000 nM
Estimate against measurement, compound 4: 6.3-fold (0.80 log units) below, and the stated range ends below it.
By their numbers in this assay, from the lowest: compound 3; then compounds 1 and 2 (each within the scatter of the next); then compound 4.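

In this assay the ring on this carbonyl carbon proves able to move the number, which the earlier pair could not show: swapping thiophen-2-yl for phenyl gives a clear rise (a 5.8-fold higher number from compound 2 to compound 4 (0.77 log units; beyond the scatter)), and removing the two chlorines from the 3,5-dichlorophenyl ring gives one of similar scale (a 7.5-fold higher number from compound 1 to compound 4 (0.88 log units; beyond the scatter)). The earlier step (a 1.3-fold higher number from compound 1 to compound 2 (0.11 log units; within the scatter)) therefore does not mean that any aromatic ring is interchangeable here, since the bare phenyl of the benzoyl group stands apart from both other rings, even though those two rings cannot be told apart from each other. No measurement shown here explains why the benzoyl compound separates from the other two.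

The compounds shown leave open which single feature matters, for instance whether one chlorine or one methoxy group on the phenyl ring, or a pyridine or cyclohexyl ring in its place, would bring the number back towards that of the other two. On these data alone, it also remains open whether the same ring swap would behave alike with the dimethylphenyl group on the sulfur in place of the hydroxyphenyl group, as that side differs in compound 3 together with its ring on the carbonyl.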